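The compounds below may be only part of what the source reports. "The series", "measured", "known", "first", "only" and "open" are said of these compounds alone.

Of the compounds shown here, three built on the same core have been tested in an assay on isolated protein for inhibition of histone deacetylase 4 (Homo sapiens), with a stated time of 1 h; a lower number here means a stronger inhibitor, a higher number a weaker inhibitor. Compound 1 `O=C(COc1ccc2cc(/C=C3/SC(=O)NC3=O)ccc2c1)Nc1cccc(C(F)(F)F)c1` gives 2500 nM. Compound 2 `Cc1cccc2sc(NC(=O)COc3ccc4cc(/C=C5/SC(=O)NC5=O)ccc4c3)nc12` gives 1200 nM, and compound 3 `Cc1ccc(NC(=O)COc2ccc3cc(/C=C4/SC(=O)NC4=O)ccc3c2)cc1Cl` gives 1100 nM. The three differ only in the group carried on an amide-type nitrogen. Going from compound 1 to compound 2 gave a 2.1-fold lower number from compound 1 to compound 2 (0.32 log units; beyond the scatter), and going from compound 1 to compound 3 gave a 2.3-fold lower number from compound 1 to compound 3 (0.36 log units; beyond the scatter); between compound 2 and compound 3 the step was a 1.1-fold lower number from compound 2 to compound 3 (0.04 log units; within the scatter). Compound 3 therefore shows the lowest number of the three, but its gap to compound 2 lies within the scatter, so those two cannot be ordered; only compound 1 stands clearly apart.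

Compound 4 `O=C(COc1ccc2cc(/C=C3/SC(=O)NC3=O)ccc2c1)Nc1ccc(Br)cc1` has not yet been measured. It differs from compound 3 in a single place: 4-bromophenyl in place of 3-chloro-4-methylphenyl on an amide-type nitrogen. All three measured steps bear on this change, since each of them also exchanges the group on that nitrogen, and they ran from within the scatter to modest in size. A step of no more than modest size is therefore expected in this assay, and the number for compound 4 is expected to move by a 1.4-fold higher number from compound 3 to compound 4 (0.13 log units; within the scatter). Compound 4 is estimated at 1500 nM, within a range from 700 nM to 3200 nM.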

Compound 4, half-maximal inhibitory concentration: 2900 nM
Estimate against measurement, compound 4: 1.9-fold (0.29 log units) below, within the range that was stated.
By their numbers in this assay, from the lowest: compounds 3 and 2 (each within the scatter of the next); then compounds 1 and 4 (each within the scatter of the next).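

In this assay the change of 3-chloro-4-methylphenyl to 4-bromophenyl on the amide-type nitrogen gives a 2.6-fold higher number from compound 3 to compound 4 (0.42 log units; beyond the scatter) and so makes a clear difference, although both groups are a six-membered aromatic ring of carbon only, with no hydrogen-bond donors or acceptors and no net charge. Replacing the 4-methyl-1,3-benzothiazol-2-yl group of compound 2 with 4-bromophenyl also gives a clear step of a 2.4-fold higher number from compound 2 to compound 4 (0.38 log units; beyond the scatter) while the exchange with the 3-(trifluoromethyl)phenyl group gives a 1.2-fold higher number from compound 1 to compound 4 (0.06 log units; within the scatter) and leaves those two compounds unordered, so this position now divides the four compounds into two pairs, compounds 2 and 3 on the lower side and compounds 1 and 4 on the higher side. Nothing available explains this division.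

The step from compound 3 to compound 4 alters the chlorine, the methyl and the bromine together, so the compounds shown do not tell which of these ring substituents matters. On these data alone, how a plain phenyl group, or a phenyl ring carrying an amine or a carboxylic acid, would read in this assay also remains open.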